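From Hexylsulfanyl to Isopropylsulfanyl at the Assay Limit

The source may hold more compounds than are shown below. What is called first, only, known or untested is meant among the compounds shown, and "the series" means these compounds.

Of the compounds shown here, three sharing one core have been tested in an ADME assay on MOLT-3 cells (Homo sapiens) for cytotoxicity, with a stated time of 7 days (a higher number here means that more compound is tolerated, a lower number that less compound is tolerated), and none of them gives a number. Compound 1 (`CNc1nc(N)nc2c1ncn2/C=C1/CC1(CO)CO`) gives > 20000 nM as a limit of the assay. Compound 2 (`CCCCCCCCOc1nc(N)nc2c1ncn2/C=C1/CC1(CO)CO`) gives > 20000 nM as a limit too. Compound 3 (`CCCCCCSc1nc(N)nc2c1ncn2/C=C1/CC1(CO)CO`) gives > 20000 nM as a limit also. Compound 3 thus stands at the limit of > 20000 nM in this assay, at which 3 of the 3 values shown sit, and has no number of its own.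

Compound 4 (`CC(C)Sc1nc(N)nc2c1ncn2/C=C1/CC1(CO)CO`) differs from it in one place, with isopropyl in place of hexyl on a sulfur. This exact change has not been measured. The nearest evidence is a step that the two limits leave unreadable from compound 1 to compound 3 and a step that the two limits leave unreadable from compound 2 to compound 3 together with a step that the two limits leave unreadable from compound 1 to compound 2 and none of these offers a size to carry over. No step beyond the scatter is therefore expected in this assay for this change. The estimate is a step that the limit leaves unreadable from compound 3 to compound 4 and nothing larger is expected. For compound 4 the estimated concentration is 22000 nM with an expected range from 9000 nM to 50000 nM and a further limit is the most probable report.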

Compound 4, half-maximal cytotoxic concentration: > 20000 nM
Compound 4 ended at the assay's limit; the forecaster's own chance of this, stated with the estimate: 80%; the middle value lies beyond the limit too.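

No step from compound 1, compound 2 or compound 3 to compound 4 can be read in this assay: the limit of > 20000 nM in this assay, at which 4 of the 4 values shown sit.

The compounds shown leave open at what concentration, if any, each one becomes cytotoxic, and whether the hexylsulfanyl and isopropylsulfanyl compounds differ at all.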